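Iodo for bromo on the sugar ring: compound 4

The source may hold more compounds than are shown below. What is called first, only, known or untested is meant among the compounds shown, and "the series" means these compounds.

Compound 2 `Nc1ccn(C2OC(CO)C(Br)C2O)c(=O)n1` gives a limit, not a number, in a functional assay on L5178Y cells (Mus musculus) for antiproliferative activity; a lower number here means a stronger inhibitor, a higher number a weaker inhibitor: > 100 ug/mL. That is the limit of > 100 ug/mL in this assay, at which 1 of the 3 values shown sits. Compound 3 `Nc1nc(=O)n(C2OC(CO)C(Br)C2O)cc1F`, with fluoro in place of hydrogen, gives 2.6 ug/mL, and the step is an at least 38-fold lower number from compound 2 to compound 3 (1.58 log units; beyond the scatter). Compound 1 `Nc1nc(=O)n(C2OC(CO)C(I)C2O)cc1F` gives 10 ug/mL, so that going from iodo to bromo the step is a 3.8-fold lower number from compound 1 to compound 3 (0.59 log units; beyond the scatter). Compound 4 `Nc1ccn(C2OC(CO)C(I)C2O)c(=O)n1` is not yet measured and differs from compound 2 by iodo in place of bromo on a saturated ring carbon. Among the compounds with values here, the one step that bears on it runs the other way, from iodo to bromo, and was modest, so compound 4 in this assay is expected to show a step that the limit leaves unreadable from compound 2 to compound 4 rather than any fall below the limit. Compound 4 is therefore estimated at 300 ug/mL, within 100 ug/mL to 1000 ug/mL, most likely reported again only as a limit.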

Compound 4, concentration for 50% inhibition: > 100 ug/mL
Compound 4: a limit, no number; the forecaster's own chance of this, stated with the estimate: 90%; the middle value lies beyond the limit too.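

Compound 4 gives only a limit in this assay, so iodo in place of bromo on the saturated ring carbon cannot be read on the core without fluoro, and the step from compound 2 cannot be read. Hydrogen in place of fluoro on the iodo core gives an at least 10-fold higher number from compound 1 to compound 4 (1.00 log units; beyond the scatter). Loss of the aromatic fluoro thus costs activity with either halogen on the sugar ring: the same change on two cores in this assay, an at least 38-fold lower number (1.58 log units; beyond the scatter) from compound 2 to compound 3 and an at least 10-fold lower number (1.00 log units; beyond the scatter) from compound 4 to compound 1; the limit leaves it open whether they differ

How far compound 2 and compound 4 lie apart stays hidden behind the limit. Also open, from the compounds shown here alone, is how chloro or an amine on that saturated ring carbon would read on the fluoro core.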